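Swapping Methyl for Chloro on a Positive Allosteric Modulator

The compounds below may be only part of what the source reports. "The series", "measured", "known", "first", "only" and "open" are said of these compounds alone.

Compound 1 `O=C(NC1CCCC1)c1ccc(C#Cc2cccnc2)nc1` gives > 10000 nM in a functional assay on HEK293 cells for positive allosteric modulation of metabotropic glutamate receptor 5 (Homo sapiens), read by FLIPR and calcium flux; a higher number here means that more compound is needed for the effect, a lower number that less compound is needed.
Compound 2 `CC(C)N1CCc2nc(C#Cc3cccnc3)ccc2C1=O` is reported in this assay as "not active" (no number reported), with no number given.
Compound 3 `Cc1cccc(C#Cc2ccc3c(n2)CCN(C2CCCC2)C3=O)c1` gives 7.5 nM in this assay.

For the measured compounds named here, of the three measured compounds, compound 3 is the only one with a real number. For compound 1 the entry is a limit of the assay, not a measured potency, and it sits at the limit of > 10000 nM in this assay, at which 1 of the 3 values shown sits. Compound 2 has no number at all, only the statement that no effect was seen. Going by the values given here, compound 3 therefore stands alone as the single point from which anything can be gauged, and no pairs of measured compounds differ in one place, so no measured step is available.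

Compound 4 `O=C1c2ccc(C#Cc3cccc(Cl)c3)nc2CCN1C1CCCC1` differs from compound 3 by chloro in place of methyl on an aromatic carbon. Each of the two groups is a single heavy atom, and neither carries a hydrogen-bond donor or acceptor. The change is expected to move potency little. The step from compound 3 to compound 4 is estimated at a 1.3-fold higher number from compound 3 to compound 4 (0.12 log units; within the scatter), which lies within the usual scatter. Compound 4 is expected to give 10 nM, with a likely range from 3 nM to 35 nM.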

Compound 4, half-maximal effective concentration: 33 nM
Beside the measured number, compound 4's estimate is 3.3-fold (0.52 log units) below it; the range from low to high includes it.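

For the compounds shown here, the swap of 3-methylphenyl to 3-chlorophenyl is the first change in this set that can be read in one place alone, since every other pair of compounds differs in more than one. In this assay it gives a 4.4-fold higher number from compound 3 to compound 4 (0.64 log units; beyond the scatter), so more of compound 4 is needed for the same effect, even though the group that leaves and the group that enters each count a single heavy atom and neither carries a hydrogen-bond donor or acceptor. This position on the aromatic ring therefore tells methyl and chloro apart, modestly but beyond the scatter, and matching heavy-atom counts did not make the two groups interchangeable here. The data at hand offer nothing that bears on the reason for this step.

Going by these compounds, whether a fluoro, a methoxy, a nitrile or an amine at this same place would give a lower or a higher number than methyl remains open. Also open, on these data alone, is whether the same swap would give a step of similar size on a different core.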